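Amide nitrogen substituent exchange: notes toward compound 4

The source may report more compounds than this note shows. Statements on the series, on what has been measured and on what is new or still open speak of the compounds shown alone.

Measured so far:
compound 1, `CCN(CC)CCNC(=O)c1ccc(C(CC)(CC)c2ccc(OCC(=O)C(C)(C)C)c(C)c2)n1CC`: 91 nM
compound 2, `CCN(CC)CCCNC(=O)c1ccc(C(CC)(CC)c2ccc(OCC(=O)C(C)(C)C)c(C)c2)n1CC`: 22 nM
compound 3, `CCN(CC)CCCNC(=O)c1ccc(C(CC)(CC)c2ccc(OCC(O)C(C)(C)C)c(C)c2)n1CC`: 66 nM

All three values come from an assay on HL-60 cells for agonist activity at vitamin D3 receptor (Homo sapiens), read by microscopy, with a stated time of 96 h; a higher number here means that more compound is needed for the effect, a lower number that less compound is needed. Compound 3 stands second highest of the three numbers; its nearest neighbour is compound 1, within the scatter, and its furthest is compound 2, beyond the scatter. Two single-point steps are known. Along the amide nitrogen chain, a 4.1-fold lower number from compound 1 to compound 2 (0.62 log units; beyond the scatter). At the chain carbon bound to the ring oxygen, a 3.0-fold higher number from compound 2 to compound 3 (0.48 log units; beyond the scatter). Both are modest.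

Compound 4, `CCn1c(C(=O)Nc2ccc(OC(F)(F)F)cc2)ccc1C(CC)(CC)c1ccc(OCC(O)C(C)(C)C)c(C)c1`, differs from compound 3 at the amide nitrogen: 4-(trifluoromethoxy)phenyl in place of 3-(diethylamino)propyl on an amide-type nitrogen. Within the data shown here, the step from compound 1 to compound 2 is the only one that touches this nitrogen, and it altered the chain length only; no measured step replaces the chain with an aromatic ring, so its bearing is indirect. The step from compound 2 to compound 3 concerns another place and does not speak to this change. With a larger, ring-bearing group entering where every measured compound carries a chain, the direction is open; a modest step toward a higher number is expected, a 2.3-fold higher number from compound 3 to compound 4 (0.36 log units; beyond the scatter). Compound 4 is therefore estimated at 150 nM, with a range from 30 nM to 700 nM.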

Compound 4, half-maximal effective concentration: > 50000 nM
Compound 4 ended at the assay's limit (the forecaster's own chance of this, stated with the estimate: 10%); at least 330-fold (2.52 log units) between middle value and limit.
By their numbers in this assay, from the lowest: compound 2; then compounds 3 and 1 (each within the scatter of the next). At a limit, above all of these: compound 4.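

In this assay compound 4 gives > 50000 nM, which is a limit of the assay and not a number: the limit of > 50000 nM in this assay, at which 1 of the 4 values shown sits.

With 4-(trifluoromethoxy)phenyl in place of 3-(diethylamino)propyl on the amide-type nitrogen, the change is an at least 750-fold higher number from compound 3 to compound 4 (2.87 log units; beyond the scatter), a large step, whereas the change in chain length gave only a modest one, a 4.1-fold lower number from compound 1 to compound 2 (0.62 log units; beyond the scatter). The amide nitrogen substituent therefore does more than tune the number within a narrow band: among the compounds shown, this one exchange is enough to take the series to the limit of the assay, with the rest of compound 3 held constant.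

This single step removes the diethylamino group and the saturated chain and brings in the aromatic ring and its trifluoromethoxy group all at once, so it does not show which of these parts accounts for the result. A plain phenyl on the same nitrogen, a phenyl ring carrying a diethylamino group, or a propyl chain ending in trifluoromethoxy rather than an amine would each bear on that question, and the compounds shown leave it open.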